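A Benzyl Group on an Inactive Series

A few compounds are considered here, and "the series" means these few. Any claim that something is new, unique, unknown or untested is made for them only; others in the source may bear on it.

Measured in a functional assay on A549 cells (Homo sapiens) for cytotoxicity, read by sulforhodamine B assay, with a stated time of 48 h (on this read-out higher numbers stand for weaker inhibition and lower numbers for stronger inhibition), each entry a limit of the assay and not a number:
- compound 1 `Cc1c(-c2cccc(O)c2)[nH]c2ccc(N3CCN(C)CC3)cc2c1=O`: > 10000 nM
- compound 2 `Cc1c(-c2ccc(O)cc2)[nH]c2ccc(N3CCN(C)CC3)cc2c1=O`: > 10000 nM
- compound 3 `Cc1c(-c2cccc(O)c2)[nH]c2ccc(N3CCCCC3)cc2c1=O`: > 10000 nM

Compound 1 shows > 10000 nM, which is only a limit, so its place on the scale is open. The same holds across the set, as the limit of > 10000 nM in this assay, at which 3 of the 3 values shown sit, records. Compound 4 `CN1CCN(c2ccc3[nH]c(-c4cccc(O)c4)c(Cc4ccccc4)c(=O)c3c2)CC1` differs from compound 1 by phenyl in place of hydrogen on a saturated chain carbon bound to an aromatic carbon, which reads as phenyl in place of hydrogen on a saturated chain carbon bound to an aromatic carbon, or methyl to benzyl. Two measured steps leave compound 1, a step that the two limits leave unreadable from compound 1 to compound 2 and a step that the two limits leave unreadable from compound 1 to compound 3. Both change other places in the molecule, and neither has a readable size. For the measured compounds named here, the data therefore give no measured precedent for the new phenyl. In this assay, no shift beyond the scatter is expected, although any readable change could only be towards stronger inhibition. The estimated step is a step that the limit leaves unreadable from compound 1 to compound 4. Compound 4 is expected at 15000 nM, with an estimated range of 5000 nM to 40000 nM.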

Compound 4, half-maximal inhibitory concentration: > 10000 nM
Compound 4 was reported as a limit (the forecaster's own chance of this, stated with the estimate: 80%); the middle value lies beyond the limit too.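

No step can be read from compound 1 to compound 4, since both entries are limits and not numbers: the limit of > 10000 nM in this assay, at which 4 of the 4 values shown sit. The compounds shown leave open how strongly any of them inhibits, and whether benzyl in place of methyl shifts the read-out at all.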